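Ethoxy in place of methoxy: a repeated small step

The compounds below may be only part of what the source reports. "The series", "measured", "known", "first", "only" and "open" are said of these compounds alone.

Measured compounds:
compound 1, `CCCCCCCC/C=C\CCCCCCCC(=O)OC[C@@H](COC)OP(=O)(O)OC[C@H](N)C(=O)O`: 12.9%
compound 2, `CCCCCCCC/C=C\CCCCCCCC(=O)OC[C@@H](COCC)OP(=O)(O)OC[C@H](N)C(=O)O`: 12.3%
compound 3, `COC[C@H](COC(=O)CCc1ccccc1OCc1cccc(Oc2ccccc2)c1)OP(=O)(O)OC[C@H](N)C(=O)O`: 13.5%

In an assay on HEK293 cells for agonist activity at probable G-protein coupled receptor 34 (Mus musculus), with a stated time of 1 h (on this read-out higher numbers stand for larger maximal responses and lower numbers for smaller maximal responses), compound 1 gives 12.9% and compound 2 gives 12.3%. The two differ by methyl in place of hydrogen on a saturated chain carbon bound to an oxygen on a saturated carbon, and the step is a number 0.6 percentage points lower from compound 1 to compound 2 (within the scatter). Compound 3 carries a different core; how the core of compound 3 differs from the core of compound 1 is not broken down here. In this assay compound 3 gives 13.5%, which lies within the scatter of both compound 1 and compound 2.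

Compound 4, `CCOC[C@H](COC(=O)CCc1ccccc1OCc1cccc(Oc2ccccc2)c1)OP(=O)(O)OC[C@H](N)C(=O)O`, has not been measured in this assay. It stands to compound 3 as compound 2 stands to compound 1: the difference is methyl in place of hydrogen on a saturated chain carbon bound to an oxygen on a saturated carbon, and the place is the same as in the earlier pair, so this is the same change made a second time, on the core of compound 3.

The step from compound 3 to compound 4 is expected to be a number 0.5 percentage points lower from compound 3 to compound 4 (within the scatter) because a number 0.6 percentage points lower from compound 1 to compound 2 (within the scatter) stayed within the scatter on the first core. Compound 4 is therefore estimated at 13%, with a range from 8% to 18%.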

Compound 4, largest response reached (Emax), in percent of the reference or control that the assay uses: 12.1%
Beside the measured number, compound 4's estimate is 0.9 percentage points above it; low and high end bracket the measured number.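

In this assay, ethoxy in place of methoxy on the core of compound 3 gives a number 1.4 percentage points lower from compound 3 to compound 4 (within the scatter), so the change again produces no step larger than the usual scatter of the measurement, as on the core of compound 1. Set side by side, the steps on the two cores do not differ: the same change on two cores in this assay, a number 0.6 percentage points lower (within the scatter) from compound 1 to compound 2 and a number 1.4 percentage points lower (within the scatter) from compound 3 to compound 4, 0.8 percentage points apart, within the scatter of two such steps. This shows that the change carries across these two cores without a distinguishable effect on the read-out, but it establishes no real size or direction for the step and gives no rule for any further core or other assay.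

The compounds shown leave open whether a longer chain in this place, such as propoxy or butoxy, would move the maximal response beyond the scatter. They also leave open what a free hydroxyl, or a chain ending in an amine or a carboxylic acid, would do there on either core.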